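Pyrrolopyrimidine amides and ureas: removal of the benzoyl group

The compounds below may be only part of what the source reports. "The series", "measured", "known", "first", "only" and "open" are said of these compounds alone.

Measured in a functional assay on A375P cells (Homo sapiens) for antiproliferative activity, read by MTT assay, with a stated time of 24 h; a higher number here means a weaker inhibitor, a lower number a stronger inhibitor:
compound 1 `O=C(Nc1ccc(-n2ccc3c(NC(=O)c4ccccc4)ncnc32)cc1)c1ccc(Cl)c(C(F)(F)F)c1` gives 2300 nM
compound 2 `Nc1ncnc2c1ccn2-c1ccc(NC(=O)Nc2cc(C(F)(F)F)cc(C(F)(F)F)c2)cc1` gives 3000 nM
compound 3 `O=C(Nc1ccc(-n2ccc3c(NC(=O)c4ccccc4)ncnc32)cc1)Nc1cc(C(F)(F)F)cc(C(F)(F)F)c1` gives 9800 nM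

Compound 4 `Nc1ncnc2c1ccn2-c1ccc(NC(=O)c2ccc(Cl)c(C(F)(F)F)c2)cc1` is not yet measured. It differs from compound 1 by hydrogen in place of benzoyl on a nitrogen on an aromatic ring. The same change was made from compound 3 to compound 2, (hydrogen in place of benzoyl on a nitrogen on an aromatic ring), where it gave a 3.3-fold lower number from compound 3 to compound 2 (0.51 log units; beyond the scatter). The difference between the two cores, compound 1 against compound 3, is not broken down here; the values of compound 1 and compound 2 lie within the scatter of each other.

For compound 4 the step is expected to resemble a 3.3-fold lower number from compound 3 to compound 2 (0.51 log units; beyond the scatter), so a step of a 2.6-fold lower number from compound 1 to compound 4 (0.41 log units; beyond the scatter) is estimated, resting on that single precedent. Compound 4 is therefore expected at 900 nM, between 350 nM and 2500 nM in this assay.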

Compound 4, half-maximal inhibitory concentration: 2900 nM
Compound 4: the middle estimate sits 3.2-fold (0.51 log units) below what was measured; the measured number lies above the stated range.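

In this assay, hydrogen in place of benzoyl on the core of compound 1 gives a 1.3-fold higher number from compound 1 to compound 4 (0.10 log units; within the scatter), so the change has no readable effect on this core. The change therefore does not carry over as a fixed step from one core to the other: the same change on two cores in this assay, a 3.3-fold lower number (0.51 log units; beyond the scatter) from compound 3 to compound 2 and a 1.3-fold higher number (0.10 log units; within the scatter) from compound 1 to compound 4, 4.1-fold (0.61 log units) apart, beyond the scatter of two such steps. This rests on a single pair for each core in one assay, and it neither explains the difference nor shows how the change would behave on any other core in the series.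

The compounds shown carry only benzoyl or hydrogen on this nitrogen, so the outcome with an acetyl group, a methyl group or a longer chain there remains open. A third core carrying the same pair would show whether either step is the more usual one.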